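The source may report more compounds than this note shows. Statements on the series, on what has been measured and on what is new or still open speak of the compounds shown alone.

Measured so far:
compound 1 `NC(=O)c1c(NC(=O)Nc2ccc(Cl)cc2)sc2c1CCN(C1CCOCC1)C2` — 2830 nM
compound 2 `CCN1CCc2c(sc(N)c2C(N)=O)C1` — > 25000 nM
compound 3 `CCC(O)c1cc2c(cc1NC(=O)Nc1ccc(Cl)cc1)OCCO2` — > 25000 nM

Notes on the series. For the measured compounds named here, in a functional assay (strain AB) with Danio rerio as the target, read by microscopy, with a stated time of 1 h (a lower number here means that less compound is needed, a higher number that more compound is needed for the effect), compound 1 gives 2830 nM, the only full number in the set. For compound 2 the value > 25000 nM is a limit of the assay and not a number. For compound 3 likewise the value > 25000 nM is a limit and not a number. Compound 1 therefore stands alone as the one measurable point, set apart from the limit of > 25000 nM in this assay, at which 2 of the 3 values shown sit; nothing more can be read from the two limits about how far apart the three compounds lie.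

Going by the values given here, no step between two measured compounds that differ in a single place is available, so no measured size of change can be quoted.

Compound 4 `COCCCN1CCc2c(sc(NC(=O)Nc3ccc(Cl)cc3)c2C(N)=O)C1` is the next compound for this assay. It differs from compound 1 in one place: 3-methoxypropyl in place of oxan-4-yl on an amine nitrogen in a ring. Both groups carry one acceptor and no donor; one is a ring, the other an open chain of five heavy atoms. Among the compounds with values here, with no measured step to lean on, the expectation is a change no larger than the usual scatter in this assay, in either direction, leaning slightly toward more compound being needed.

For compound 4 the estimate is 3500 nM, expected between 1400 nM and 9000 nM. The expected step is a 1.2-fold higher number from compound 1 to compound 4 (0.09 log units; within the scatter).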

Compound 4, half-maximal effective concentration: 2400 nM
Estimate against measurement, compound 4: 1.5-fold (0.16 log units) above; measured number inside the range.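

In this assay, for the compounds shown here, 3-methoxypropyl in place of oxan-4-yl on an amine nitrogen in a ring gives a 1.2-fold lower number from compound 1 to compound 4 (0.07 log units; within the scatter), the first measured step. Compound 1 and compound 4 therefore cannot be told apart in this read-out, so the six-membered non-aromatic ring of oxan-4-yl is not required at this position, at least when the open chain that replaces it has the same counts of hydrogen-bond donors and acceptors. Compound 2 and compound 3 still give only a limit of the assay and not a number, so the series now has two full numbers alongside them: the limit of > 25000 nM in this assay, at which 2 of the 4 values shown sit.

Both groups at this position carry an oxygen, so the compounds shown leave open whether that oxygen matters; a plain butyl chain on the same nitrogen would separate its contribution from that of chain length. A group of a different kind at this position, such as a carboxylic acid or a primary amine at the end of the chain, also remains open, and the single step shown says nothing about how such groups would read.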